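From oxan-4-yl to 2-methylfuran-3-yl on a carbonyl carbon

This account rests on a few compounds, and the source may have more. Where it says the series, first, only, none or still open, it means among the compounds named here.

Three compounds have numbers so far in a physicochemical assay for lipophilicity, read by HPLC, with a stated time of 90 min, tested at 100 uM (on this read-out higher numbers stand for higher lipophilicity and lower numbers for lower lipophilicity), as follows:

Compound 1 `O=C(Nc1ccc(OC(F)(F)F)c(F)c1)NC1CCN(C(=O)C2(C(F)(F)F)CC2)CC1` gives 5.94
Compound 2 `O=C(Nc1ccc(OC(F)(F)F)c(F)c1)NC1CCN(C(=O)C2CC2)CC1` gives 4.19
Compound 3 `O=C(Nc1ccc(OC(F)(F)F)cc1)NC1CCN(C(=O)C2CCOCC2)CC1` gives 3.26

Compound 3 stands lowest of the three, and its gaps to both others lie beyond the scatter. Of the two, compound 2 at 4.19 is nearest to it and compound 1 at 5.94 is furthest away.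

Compound 4 `Cc1occc1C(=O)N1CCC(NC(=O)Nc2ccc(OC(F)(F)F)cc2)CC1` has not yet been measured. It comes from compound 3 through a single exchange 2-methylfuran-3-yl in place of oxan-4-yl on a carbonyl carbon in which 2-methylfuran-3-yl stands in place of oxan-4-yl on a carbonyl carbon.

Within the data shown here, no measured step covers this exchange. Among the measured compounds shown here, the one available step is a number 1.75 log units lower from compound 1 to compound 2 (beyond the scatter) and it is large and beyond the scatter. It puts hydrogen in place of trifluoromethyl on a saturated ring carbon, so it bears only loosely on the new change. It does show that the number can move far when the group on this carbonyl changes. With compound 3 at the bottom of the range, a moderate rise beyond the scatter is expected in this assay here, though the data give no direct measure of it.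

The expected step is a number 0.84 log units higher from compound 3 to compound 4 (beyond the scatter) by this estimate. For compound 4 the estimated value is 4.1 with an expected range from 3.6 to 4.6 for now.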

Compound 4, partition coefficient: 4.3
Beside the measured number, compound 4's estimate is 0.20 log units below it; low and high end bracket the measured number.
By their numbers in this assay, from the lowest: compound 3; then compounds 2 and 4 (each within the scatter of the next); then compound 1.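

In this assay, the exchange on a carbonyl carbon whose other neighbour is an amide-type nitrogen in a ring now has a direct measure, a number 1.04 log units higher from compound 3 to compound 4 (beyond the scatter), and this large step lies beyond the scatter. The earlier step, a number 1.75 log units lower from compound 1 to compound 2 (beyond the scatter), replaced trifluoromethyl with hydrogen and so changed the size of the group, whereas oxan-4-yl and 2-methylfuran-3-yl have the same heavy-atom, carbon, oxygen, hydrogen-bond donor and hydrogen-bond acceptor counts and no net charge, which shows that the number at this position can move far even when all these counts stay the same. What the exchange does change is the ring, from a six-membered non-aromatic one to a five-membered aromatic one that carries a methyl group, but no measurement here gives a reason for the size of the step.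

The compounds shown leave open how much of the step belongs to the furan ring and how much to its methyl group, a question that an unsubstituted furan-3-yl group would address. They also leave open whether a phenyl ring or a group bearing a carboxylic acid or an amine on this carbonyl would move the number in the same direction.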